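Thiosemicarbazone aryl swap: nitrophenyl for dimethylaminophenyl

This account rests on a few compounds, and the source may have more. Where it says the series, first, only, none or still open, it means among the compounds named here.

Compound 2 `CC1=CC[C@@H]([C@@](C)(O)CCCC(C)(C)NC(=S)N/N=C\c2ccc(N(C)C)cc2)CC1` is known only by a limit: in a functional assay on K562 cells (Homo sapiens) for cytotoxicity, read by sulforhodamine B assay (a higher number here means that more compound is tolerated, a lower number that less compound is tolerated), compound 2 gives > 100000 nM, a limit of the assay. Compound 1 `CC1=CC[C@@H]([C@@](C)(O)CCCC(C)(C)NC(=S)N/N=C\c2ccc(O)cc2)CC1` likewise reaches only a limit, giving > 100000 nM in this assay. The step that the two limits leave unreadable from compound 1 to compound 2 cannot be read, and the limit of > 100000 nM in this assay, at which 2 of the 2 values shown sit, is all the two values show. Compound 3 `CC1=CC[C@@H]([C@@](C)(O)CCCC(C)(C)NC(=S)N/N=C\c2ccccc2[N+](=O)[O-])CC1` differs from compound 2 by 2-nitrophenyl in place of 4-(dimethylamino)phenyl on a carbon with a double bond to nitrogen. No readable step bears on this change. The step that the limit leaves unreadable from compound 2 to compound 3 is expected to be none beyond the scatter, most probably another limit. Compound 3 is estimated at 150000 nM, between 40000 nM and 600000 nM.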

Compound 3, concentration lethal to 50% of the cells: > 100000 nM
Compound 3 gave a limit, no number; the forecaster's own chance of this, stated with the estimate: 80%; the middle value is on the limit's open side.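

No step among compound 1, compound 2 and compound 3 can be read in this assay, because all three stop at a limit: the limit of > 100000 nM in this assay, at which 3 of the 3 values shown sit.

From the compounds shown here alone, how far these three compounds actually differ in this assay stays open.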